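The compounds below may be only part of what the source reports. "The series", "measured", "known", "first", "only" and "open" are said of these compounds alone.

Measured so far in an ADME assay on S9 fraction from liver (Rattus norvegicus) for metabolic stability, with a stated time of 1 h; on this read-out higher numbers stand for a more stable compound and lower numbers for a less stable compound:
- compound 1 `N#Cc1cnc(NCc2cnccc2C(F)(F)F)cc1NC[C@H]1C[C@H](O)C1`: 61%
- compound 2 `N#Cc1cnc(NCc2cnccc2C(F)(F)F)cc1NC[C@H]1CC[C@@H](O)CC1`: 18%
- compound 3 `N#Cc1cnc(NCc2cnccc2C(F)(F)F)cc1NC[C@H]1CC[C@H](O)CC1`: 6%

Compound 1 stands highest of the three, and both other compounds lie beyond the scatter from it. Compound 4 `N#Cc1cnc(NCc2cnccc2C(F)(F)F)cc1NCCC1CCOCC1` has not yet been measured. Its difference from compound 1 is (oxan-4-yl)methyl in place of 3-hydroxycyclobutyl on a saturated chain carbon bound to a nitrogen on an aromatic ring.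

Within the data shown here, the steps that bear on this change are the two at the same place, where 4-hydroxycyclohexyl enters: a number 43 percentage points lower from compound 1 to compound 2 (beyond the scatter) and a number 55 percentage points lower from compound 1 to compound 3 (beyond the scatter). Both are large. A further, modest step, a number 12 percentage points lower from compound 2 to compound 3 (beyond the scatter), goes with the fact that compounds 2 and 3 differ only in the configuration as drawn. None of these steps removes the hydrogen-bond donor, so they guide the expectation only in part. A large downward step is still expected, though probably smaller than those two. The expected step is a number 33 percentage points lower from compound 1 to compound 4 (beyond the scatter). For compound 4 the estimate is 28%, with an expected range of 8% to 55%.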

Compound 4, percent of the compound remaining: 0%
Estimate against measurement, compound 4: 28 percentage points above; measured number outside the range, below it.
By their numbers in this assay, from the lowest: compounds 4 and 3 (each within the scatter of the next); then compound 2; then compound 1.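

In this assay the change on a saturated chain carbon bound to a nitrogen on an aromatic ring is large (a number 61 percentage points lower from compound 1 to compound 4 (beyond the scatter)), even though the entering (oxan-4-yl)methyl carries no hydrogen-bond donor. Set against the 4-hydroxycyclohexyl compounds, compound 4 cannot be told apart from compound 3 (a number 6 percentage points lower from compound 3 to compound 4 (within the scatter)) and lies under compound 2 (a number 18 percentage points lower from compound 2 to compound 4 (beyond the scatter)), so a six-membered ring without the hydroxyl brings no recovery towards compound 1 on this read-out. The one structural note available concerns only the configuration of two other compounds and gives no explanation of this result.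

Compound 4 changes the ring, the hydroxyl and the chain together, so the compounds shown leave open which of these carries the step. A plain cyclobutyl or an oxetan-3-yl on the same chain would begin to separate them.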